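Chloro added to the fused ring of compound 3

The source may report more compounds than this note shows. Statements on the series, on what has been measured and on what is new or still open speak of the compounds shown alone.

Of the compounds shown here, three of one shared core have been measured in a functional assay on cells (Cancer cell lines, Homo sapiens) for cytotoxicity, read by sulforhodamine B assay, with a stated time of 48 h; a higher number here means a weaker inhibitor of growth, a lower number a stronger inhibitor of growth. Compound 1 `O=C1N=C(N2N=C(c3ccccc3)CC2c2ccccc2O)S/C1=C1/C(=O)Nc2ccccc21` gives 1990 nM, compound 2 `O=C1N=C(N2N=C(c3ccccc3)CC2c2ccc(Cl)cc2)S/C1=C1/C(=O)Nc2ccccc21` gives 190 nM, and compound 3 `CN(C)c1ccc(C2CC(c3ccccc3)=NN2C2=NC(=O)/C(=C3\C(=O)Nc4ccccc43)S2)cc1` gives 2550 nM. Compound 3 thus stands at the highest number of the three; compound 1 sits close to it, with a 1.3-fold higher number from compound 1 to compound 3 (0.11 log units; within the scatter), whereas compound 2 is far from it, with a 13-fold higher number from compound 2 to compound 3 (1.13 log units; beyond the scatter). The step of a 10-fold lower number from compound 1 to compound 2 (1.02 log units; beyond the scatter) shows the same wide spread.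

Compound 4 `CN(C)c1ccc(C2CC(c3ccccc3)=NN2C2=NC(=O)/C(=C3\C(=O)Nc4ccc(Cl)cc43)S2)cc1` is compound 3 with one change: chloro in place of hydrogen on an aromatic carbon. Every measured step, however, changes the group on the saturated ring carbon, not the fused ring. Going by the values given here, the large step of a 13-fold higher number from compound 2 to compound 3 (1.13 log units; beyond the scatter) and the large step of a 10-fold lower number from compound 1 to compound 2 (1.02 log units; beyond the scatter) concern a chloro on a different ring, so they do not bear directly on this change; no measured pair tests a chloro on the fused ring at all. The account therefore expects, for this assay, a step of a 1.6-fold lower number from compound 3 to compound 4 (0.20 log units; within the scatter) that is small and of uncertain direction. Compound 4 is estimated at 1600 nM, with a range from 350 nM to 7000 nM.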

Compound 4, concentration for 50% growth inhibition: 190 nM
Compound 4: the middle estimate sits 8.4-fold (0.93 log units) above what was measured; measured number outside the range, below it.
By their numbers in this assay, from the lowest: compounds 2 and 4 (each within the scatter of the next); then compounds 1 and 3 (each within the scatter of the next).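

Going by these compounds alone, the step of a 13-fold lower number from compound 3 to compound 4 (1.13 log units; beyond the scatter) in this assay shows that this aromatic carbon of the fused ring, which no earlier pair touched, is far from silent: a single chlorine atom in place of hydrogen is the whole change. Until now every large step had come from the group on the saturated ring carbon, as in a 13-fold higher number from compound 2 to compound 3 (1.13 log units; beyond the scatter), and this step shows that a change elsewhere on the shared core can move the number just as far while the 4-(dimethylamino)phenyl group stays in place. No measurement on hand explains why this chloro has so large an effect.

The compounds shown do not tell whether the same chloro would give a step of this size with the 2-hydroxyphenyl group of compound 1 or the 4-chlorophenyl group of compound 2 on the saturated ring carbon. Nor do they tell whether fluoro, bromo or a methoxy group on this same aromatic carbon would act as chloro does, or whether chloro alone among such groups brings the number down this far.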